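This account rests on a few compounds, and the source may have more. Where it says the series, first, only, none or still open, it means among the compounds named here.

The measured compounds:
compound 1, `Cc1nc(N)c2c(-c3ccccc3)cn([C@@H]3O[C@H](CO)[C@@H](O)[C@H]3O)c2n1`: > 100000 nM
compound 2, `Cc1nc(N)c2c(I)cn([C@@H]3O[C@H](CO)[C@@H](O)[C@H]3O)c2n1`: > 20000 nM
compound 3, `CNc1ncnc2c1c(I)cn2[C@@H]1O[C@H](CO)[C@@H](O)[C@H]1O`: > 100000 nM

In a functional assay on HCT-116 cells (Homo sapiens), read by MTT assay, with a stated time of 72 h (a higher number here means a weaker inhibitor, a lower number a stronger inhibitor), compound 1 gives > 100000 nM, which is a limit of the assay rather than a number. Compound 2 gives > 20000 nM in this assay, again a limit. Compound 3 likewise gives > 100000 nM, also a limit. The change from compound 2 to compound 1 is phenyl in place of iodo on an aromatic carbon and its step is a step that the two limits leave unreadable from compound 2 to compound 1. Two of the three values sit at the limit of > 100000 nM in this assay, at which 2 of the 3 values shown sit, and one at the limit of > 20000 nM in this assay, at which 1 of the 3 values shown sits, so no ordering among the three can be read. The cores of compound 2 and compound 3 have the same atoms joined differently; the difference between the two cores is not broken down here.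

Compound 4, `CNc1ncnc2c1c(-c1ccccc1)cn2[C@@H]1O[C@H](CO)[C@@H](O)[C@H]1O`, is not yet measured. It differs from compound 3 by phenyl in place of iodo on an aromatic carbon, the same change as that from compound 2 to compound 1, at a place described in the same words. That earlier step is not readable, so it gives no direction for the new one. The expectation for compound 4 therefore rests on compound 3 sitting at a limit > 100000 nM and on the change having shown no readable effect once. Compound 4 is expected near 100000 nM in this assay. The expected step is a number no higher from compound 3 to compound 4 (the limit leaves the size open). The expected range runs from 30000 nM to 300000 nM, most likely reported as a limit.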

Compound 4, half-maximal inhibitory concentration: > 20000 nM
Compound 4 gave a limit, no number; the forecaster's own chance of this, stated with the estimate: 85%; the middle value lies beyond the limit too.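

In this assay compound 4 gives > 20000 nM, which is a limit of the assay and not a number. Compound 3 gives > 100000 nM, also a limit, and no step can be read from compound 3 to compound 4. The compounds shown leave open whether phenyl in place of iodo on an aromatic carbon changes the read-out at all: all four values are limits.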